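A few compounds are considered here, and "the series" means these few. Any claim that something is new, unique, unknown or untested is made for them only; others in the source may bear on it.

In an ADME assay for permeability, using PAMPA, with a stated time of 30 min, at pH 7.4 (on this read-out lower numbers stand for lower permeability and higher numbers for higher permeability), compound 1 `COc1ccc(-c2ccc3c(NCCCNCc4cccc(OC)c4O)ccnc3c2)cc1` gives 237 10^-6 cm/s as its reading. Compound 3 `COc1ccc(Oc2ccc3c(NCCCNCc4cc(F)ccc4OC)ccnc3c2)cc1` stands within the scatter of that number at 317 10^-6 cm/s while compound 2 `CC(C)Cc1ccc2c(NCCCNCc3ccco3)ccnc2c1` reads 23 10^-6 cm/s and so falls clearly lower than both. Compound 4 `COc1cccc(CNCCCNc2ccnc3cc(Cc4ccc(F)cc4)ccc23)c1O` has not yet been measured. It differs from compound 1 by 4-fluorobenzyl in place of 4-methoxyphenyl on an aromatic carbon and nowhere else. Among the measured compounds shown here, no two measured compounds differ in only one place, so nothing here shows directly what such a swap does. The expectation therefore stays with compound 1 at 237 10^-6 cm/s and no change beyond the scatter. The estimated step of a 1.1-fold higher number from compound 1 to compound 4 (0.02 log units; within the scatter) is accordingly small. For compound 4 the estimated value is 250 10^-6 cm/s with 100 10^-6 cm/s to 500 10^-6 cm/s as the expected range.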

Compound 4, apparent permeability: 23 10^-6 cm/s
Beside the measured number, compound 4's estimate is 11-fold (1.04 log units) above it, outside the stated range (below it).
By their numbers in this assay, from the lowest: compounds 2 and 4 (each within the scatter of the next); then compounds 1 and 3 (each within the scatter of the next).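

In this assay, among the compounds shown here, this is the first comparison of two compounds that differ in one place, and it shows that the group at this position on the shared core can matter greatly: 4-fluorobenzyl in place of 4-methoxyphenyl gives a 10-fold lower number from compound 1 to compound 4 (1.01 log units; beyond the scatter) on an otherwise unchanged structure. The two groups have equal heavy-atom counts and each carries one six-membered aromatic ring, yet the swap is far from neutral. Nothing measured here explains the drop. The compounds shown leave open whether 4-fluorophenyl or unsubstituted benzyl would read nearer compound 1 or compound 4, so the step cannot yet be divided among the parts of the swap.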